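The source may hold more compounds than are shown below. What is called first, only, known or untested is meant among the compounds shown, and "the series" means these compounds.

Series notes. Compound 1 `CCCCN(O)C(=O)Nc1cc([C@@H]2CC[C@@H](c3cc(OC)c(OC)c(OC)c3)O2)cc(OC)c1OCCS(=O)(=O)c1ccc(Br)cc1` and compound 2 `CCCCN(O)C(=O)Nc1cc([C@@H]2CC[C@@H](c3cc(OC)c(OC)c(OC)c3)O2)cc(OC)c1OCCS(=O)(=O)c1ccccc1Br` share one core and differ only in the bromophenyl on the sulfonyl sulfur. In an assay for displacement of a labelled ligand from platelet-activating factor receptor (Homo sapiens) (a lower number here means a stronger inhibitor, a higher number a weaker inhibitor), compound 1 gives 38 nM and compound 2 gives 25 nM. The step of a 1.5-fold lower number from compound 1 to compound 2 (0.18 log units; within the scatter) is within the scatter, so compound 2 stands at the low end of the two numbers without being separated from compound 1. Compound 3 `CCCCN(O)C(=O)Nc1cc([C@@H]2CC[C@@H](c3cc(OC)c(OC)c(OC)c3)O2)cc(OC)c1OCCSc1ccc(OC)cc1` is not yet measured; it differs from compound 2 by (4-methoxyphenyl)sulfanyl in place of (2-bromophenyl)sulfonyl on a saturated chain carbon, two bonds along the chain from an oxygen on an aromatic ring. Going by the values given here, the only measured step, a 1.5-fold lower number from compound 1 to compound 2 (0.18 log units; within the scatter), concerns nothing but which bromophenyl sits on the sulfonyl sulfur; no measured pair speaks to exchanging a sulfonyl for a sulfanyl or a bromine for a methoxy. The expected step of a 1.6-fold higher number from compound 2 to compound 3 (0.20 log units; within the scatter) therefore has no measured direction to rest on, and a number near that of compound 2 is expected, with a wide band. For compound 3 the estimate in this assay is 40 nM, in the range 12 nM to 150 nM.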

Compound 3, half-maximal inhibitory concentration: 39 nM
The estimate for compound 3 lay 1.0-fold (0.01 log units) above the measured number; low and high end bracket the measured number.
By their numbers in this assay, from the lowest: compounds 2, 1 and 3 (each within the scatter of the next).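

In this assay, the whole group on the saturated chain carbon, two bonds along the chain from an oxygen on an aromatic ring, can be exchanged with a 1.6-fold higher number from compound 2 to compound 3 (0.19 log units; within the scatter) and a 1.0-fold higher number from compound 1 to compound 3 (0.01 log units; within the scatter) as the two steps, neither beyond the scatter. The earlier pair covered only the bromophenyl on the sulfonyl sulfur, whereas these steps show that, among these three compounds, neither the sulfonyl nor the bromine is needed for a number in this range. No supporting measurement bears on why the numbers stay together.

These steps carry the exchange of sulfonyl for sulfanyl and of bromine for methoxy together, so neither can be read alone. Open too, as far as these compounds go, is whether an amine or a carboxylic acid at the chain end, or a longer chain in place of the ethyl link, would keep the number in this range.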